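Homologation at the alkyl chain of the aminopyridazinone core

This account rests on a few compounds, and the source may have more. Where it says the series, first, only, none or still open, it means among the compounds named here.

Three compounds share the core and the aryl-piperazine-propyl side chain. Compound 1 `CCC(=O)c1c(C)nn(CCCN2CCN(c3ccc(C)cc3)CC2)c(=O)c1N` carries a propanoyl group; in a functional assay on the whole organism (Abdomen, strain Swiss) for inhibition, with Mus musculus as the target, with stated times of 30 min, 10 min and 5 min, at a dose of 10 mg/kg by the oral route (on this read-out higher numbers stand for a stronger effect at the one dose given and lower numbers for a weaker effect), compound 1 gives 9%. Compound 2 `CCCC(=O)c1c(C)nn(CCCN2CCN(c3ccc(C)cc3)CC2)c(=O)c1N` differs by methyl in place of hydrogen on a saturated chain carbon, two bonds along the chain from a carbonyl carbon, and in this assay compound 2 gives 0%, a step of a number 9 percentage points lower from compound 1 to compound 2 (within the scatter). Compound 3 `C=Cc1c(CC)nn(CCCN2CCN(c3ccc(C)cc3)CC2)c(=O)c1N` carries a vinyl group and an ethyl group in place of the acyl and methyl groups; the difference between the core of compound 3 and the core of compound 1 is not broken down here. In this assay compound 3 gives 0%, level with compound 2 at the digits printed.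

Compound 4 `C=Cc1c(CCC)nn(CCCN2CCN(c3ccc(C)cc3)CC2)c(=O)c1N` is not yet measured. It differs from compound 3 by methyl in place of hydrogen on a saturated chain carbon, two bonds along the chain from an aromatic carbon. This is the same kind of change as from compound 1 to compound 2, though the place differs: there the chain carbon sits two bonds along the chain from a carbonyl carbon, here two bonds along the chain from an aromatic carbon. Given that the earlier step was within the scatter and that compound 3 sits at 0%, the step from compound 3 to compound 4 is expected to be a number 2 percentage points higher from compound 3 to compound 4 (within the scatter). Compound 4 is therefore estimated at 2% in this assay, between 0% and 10%.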

Compound 4, a percentage reported as inhibition, in the whole organism at one dose (the size of the read-out at that dose, not a potency): 3%
For compound 4 the middle estimate is 1 percentage points below the measured one; the range from low to high includes it.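

In this assay the added methyl gives a step of a number 3 percentage points higher from compound 3 to compound 4 (within the scatter). Set beside the same change on the core of compound 1, the two steps do not differ: the same change on two cores in this assay, a number 9 percentage points lower (within the scatter) from compound 1 to compound 2 and a number 3 percentage points higher (within the scatter) from compound 3 to compound 4, 12 percentage points apart, within the scatter of two such steps. Going by these compounds alone, this shows that, at the one dose given, the change behaves alike on these two cores within the scatter, but it does not show that the change is without effect or that it would transfer to other cores, since only two pairs are available, the change sits two bonds along the chain from a carbonyl carbon in one and from an aromatic carbon in the other, and every step here lies within the scatter.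

The compounds shown leave open whether a longer chain than propyl, or an amine or a carboxylic acid at the end of that chain, would give a step beyond the scatter. They also leave open how the change would read on a core with a stronger effect at this dose, and whether it would give a stronger or weaker effect at other doses.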